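A few compounds are considered here, and "the series" means these few. Any claim that something is new, unique, unknown or untested is made for them only; others in the source may bear on it.

Measured so far:
compound 1 `O=C(Nc1cc(C(F)(F)F)cc(C(F)(F)F)c1)C1CCc2ccccc2N1C(=O)c1cccc(Cl)c1`: 1050 nM
compound 2 `CCCC(=O)N1c2ccccc2CCC1C(=O)Nc1ccccc1C(F)(F)F`: > 70000 nM
compound 3 `O=C(Nc1ccccc1C(F)(F)F)C1CCc2ccccc2N1C(=O)c1ccc(Cl)cc1`: 786 nM

In a functional assay on PC-3 cells (Homo sapiens) for cytotoxicity, read by sulforhodamine B assay, with a stated time of 72 h (on this read-out higher numbers stand for weaker inhibition of growth and lower numbers for stronger inhibition of growth), compound 1 gives 1050 nM, the highest of the two numbers here. Compound 3 gives 786 nM, and the gap between compound 1 and compound 3 is within the scatter, so no order is read between them. For compound 2 the assay returns only a limit, > 70000 nM, not a number. Among the compounds with values here, the single measured step, an at least 89-fold lower number from compound 2 to compound 3 (1.94 log units; beyond the scatter), runs from propyl on the carbonyl carbon to 4-chlorophenyl there; its size is only a lower bound because of the limit of > 70000 nM in this assay, at which 1 of the 3 values shown sits.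

Compound 4 `CCCCCCCCC(=O)N1c2ccccc2CCC1C(=O)Nc1cc(C(F)(F)F)cc(C(F)(F)F)c1` is not yet measured. Against compound 1 the change is octyl in place of 3-chlorophenyl on a carbonyl carbon. Within the data shown here, this reverses the direction of the measured step: 3-chlorophenyl on the carbonyl carbon leaves and octyl enters, though octyl is far longer than propyl and no measured compound carries a chain of that length. The expectation in this assay is therefore a higher number, probably a large step, with a real chance that only a limit is returned. Compound 4 is estimated at 20000 nM, range 4000 nM to 100000 nM. That estimate corresponds to an expected step of a 19-fold higher number from compound 1 to compound 4 (1.28 log units; beyond the scatter).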

Compound 4, concentration for 50% growth inhibition: 7430 nM
Compound 4: the middle estimate sits 2.7-fold (0.43 log units) above what was measured; low and high end bracket the measured number.
By their numbers in this assay, from the lowest: compounds 3 and 1 (each within the scatter of the next); then compound 4. At a limit, above all of these: compound 2.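

With the rest of compound 1 unchanged, replacing the aromatic group on the carbonyl carbon with an open chain gives a 7.1-fold higher number from compound 1 to compound 4 (0.85 log units; beyond the scatter) in this assay. This position therefore tolerates the loss of the ring without losing a measurable number, since compound 4 still gives 7430 nM, although the change costs growth inhibition on this read-out. Compound 2, which carries propyl at this position, gives only a limit and not a number: the limit of > 70000 nM in this assay, at which 1 of the 4 values shown sits.

Compound 2 and compound 4 differ in more than one place, so the contribution of chain length alone cannot be read from them. As far as these compounds go, it remains open how a longer chain, an amine or a carboxylic acid in place of octyl on the carbonyl carbon would read.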